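From methylamino to dimethylamino on compound 3

This account rests on a few compounds, and the source may have more. Where it says the series, first, only, none or still open, it means among the compounds named here.

- compound 1 `C#Cc1cn([C@@H]2O[C@H](CO)[C@@H](O)[C@H]2O)c2ncnc(OC)c12` gives 3490 nM
- compound 2 `CNc1ncnc2c1c(-c1ccco1)cn2[C@@H]1O[C@H](CO)[C@@H](O)[C@H]1O` gives > 20000 nM (a limit, not a number)
- compound 3 `C#Cc1cn([C@@H]2O[C@H](CO)[C@@H](O)[C@H]2O)c2ncnc(NC)c12` gives 18500 nM

All three were read in a functional assay on CEM-DNR-bulk cells (Homo sapiens), read by MTT assay, with a stated time of 72 h (on this read-out higher numbers stand for weaker inhibition and lower numbers for stronger inhibition), under the same conditions. Compound 3 holds the higher of the two actual numbers, and compound 1 is nearest, with a 5.3-fold higher number from compound 1 to compound 3 (0.72 log units; beyond the scatter) as the step. Compound 4 `C#Cc1cn([C@@H]2O[C@H](CO)[C@@H](O)[C@H]2O)c2ncnc(N(C)C)c12` carries methyl in place of hydrogen on a nitrogen on an aromatic ring as its change, methyl in place of hydrogen on a nitrogen on an aromatic ring. The step from compound 1 is the only measured one that touches this group, and it swaps methoxy for methylamino rather than adding methyl. The other step, an at least 1.0-fold lower number from compound 2 to compound 3 (0.03 log units; that floor lies within the scatter), concerns a different place and sets no size here. No step beyond the scatter is therefore expected in this assay and a 1.2-fold lower number from compound 3 to compound 4 (0.09 log units; within the scatter) is the estimated step. For compound 4 the estimated value is 15000 nM with an expected range of 4000 nM to 20000 nM as its span.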

Compound 4, half-maximal inhibitory concentration: 240 nM
The estimate for compound 4 lay 63-fold (1.80 log units) above the measured number, outside the stated range (below it).
By their numbers in this assay, from the lowest: compound 4; then compound 1; then compound 3. At a limit, above all of these: compound 2.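

In this assay, one added methyl on the nitrogen on an aromatic ring changes the result sharply: a 77-fold lower number from compound 3 to compound 4 (1.89 log units; beyond the scatter). Dimethylamino also improves on methoxy, with a 15-fold lower number from compound 1 to compound 4 (1.16 log units; beyond the scatter), although methylamino gave a higher number than methoxy, so the three groups form no steady trend with methyl count on this nitrogen. Nothing measured here accounts for the size of this step.

As far as these compounds go, an unsubstituted amino group and diethylamino remain open in this place, so the limits of the effect are undefined. From the compounds shown here alone, whether dimethylamino keeps its effect with furan-2-yl in place of ethynyl also remains open.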